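Furan in Place of Hydroxynaphthyl on the Shared Core

This account rests on a few compounds, and the source may have more. Where it says the series, first, only, none or still open, it means among the compounds named here.

In a functional assay on Ehrlich cells (Mus musculus) for antiproliferative activity, read by trypan blue exclusion, with a stated time of 2 h, tested at 10 ug/mL (a higher number here means a stronger effect of the compound at the concentration tested, a lower number a weaker effect), compound 1 `N#CC1=C(N)N(c2ccc(S(N)(=O)=O)cc2)C2=C(C(=O)CCC2)C1c1ccc(Cl)cc1Cl` gives 40%, while compound 2 `N#CC1=C(N)N(c2ccc(S(N)(=O)=O)cc2)C2=C(C(=O)CCC2)C1c1c(O)ccc2ccccc12` gives 0% and so stands lowest of the two numbers. For the measured compounds named here, the only step measured is a number 40 percentage points lower from compound 1 to compound 2 (beyond the scatter). Compound 3 `N#CC1=C(N)N(c2ccc(S(N)(=O)=O)cc2)C2=C(C(=O)CCC2)C1c1ccco1` carries furan-2-yl in place of 2-hydroxynaphthalen-1-yl on a saturated ring carbon. That step shows the group on this saturated ring carbon can move this assay strongly, but furan-2-yl resembles neither earlier group, so the direction is uncertain. Compound 3 is expected to recover part of the lost effect, with a number 20 percentage points higher from compound 2 to compound 3 (beyond the scatter), an estimate of 20% within 0% to 45%.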

Compound 3, a percentage reported as activity, at one concentration (the size of the read-out at that concentration, not a potency): 0%
Beside the measured number, compound 3's estimate is 20 percentage points above it, and the stated range covers the measured number.
By their numbers in this assay, from the lowest: compounds 2 and 3 (each within the scatter of the next); then compound 1.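

With the move to furan-2-yl, this assay shows no change at the digits printed from compound 2 to compound 3 (within the scatter), so neither removing the hydrogen-bond donor nor going from two six-membered aromatic rings to one five-membered aromatic ring brings the effect back. Replacing 2,4-dichlorophenyl with furan-2-yl gives a number 40 percentage points lower from compound 1 to compound 3 (beyond the scatter), which leaves compound 1 alone in showing an effect among these three compounds. Nothing available here explains this result. On these data alone, what remains open is whether the effect of compound 1 needs both chlorines, and whether plain phenyl or 4-chlorophenyl on this saturated ring carbon would retain it.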